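Swapping a Hydroxyl Hydrogen for Acetyl: an Expected Cytotoxicity

This account rests on a few compounds, and the source may have more. Where it says the series, first, only, none or still open, it means among the compounds named here.

Three compounds have been measured in a functional assay on KB cells (Homo sapiens) for cytotoxicity; a lower number here means that less compound is needed, a higher number that more compound is needed for the effect:

Compound 1, `CCC[C@@H](OC(C)=O)C1=C(Br)C(=C(Br)Br)OC1=O`, gives 0.5 ug/mL.
Compound 2, `CCC[C@@H](O)C1=C(Br)C(=C(Br)Br)OC1=O`, gives 0.6 ug/mL.
Compound 3, `CCC[C@@H](O)C1=C(Br)/C(=C/I)OC1=O`, gives 4.1 ug/mL.

Compound 1 and compound 2 share one core and differ in a single place: acetyl in place of hydrogen on an oxygen on a saturated carbon. The step that this change made is a 1.2-fold lower number from compound 2 to compound 1 (0.08 log units; within the scatter), so the two values cannot be told apart.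

Compound 3 carries a different core; how it differs from the core of compound 2 is not broken down here. Its value sits apart from the other two: next to compound 2 it reads higher by a gap that lies beyond the scatter, and next to compound 1 by a still larger gap, also beyond the scatter.

Compound 4, `CCC[C@@H](OC(C)=O)C1=C(Br)/C(=C/I)OC1=O`, has not been measured. It stands to compound 3 as compound 1 stands to compound 2: acetyl in place of hydrogen on an oxygen on a saturated carbon. The place of the change is described in the same words for both pairs, so this is the same change made on a second core.

Going by the values given here, the one example of this change gave a step that is within the scatter, which is the only ground for an expectation here. Among the compounds with values here, on a different core the outcome might differ, but with no second example the best estimate is an equally small step, a 1.1-fold lower number from compound 3 to compound 4 (0.03 log units; within the scatter), expected from the result a 1.2-fold lower number from compound 2 to compound 1 (0.08 log units; within the scatter). Compound 4 is therefore estimated at 3.8 ug/mL in this assay, most likely between 1.8 ug/mL and 8 ug/mL.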

Compound 4, concentration for half-maximal effect: 3.6 ug/mL
Compound 4: the middle estimate sits 1.1-fold (0.02 log units) above what was measured; low and high end bracket the measured number.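

On the second core, replacing the hydroxyl hydrogen with acetyl (hydroxy to acetoxy) gave, in this assay, a 1.1-fold lower number from compound 3 to compound 4 (0.06 log units; within the scatter), so here too the change has no effect that can be told apart from ordinary measurement noise. Set side by side, the two results agree: the same change on two cores in this assay, a 1.2-fold lower number (0.08 log units; within the scatter) from compound 2 to compound 1 and a 1.1-fold lower number (0.06 log units; within the scatter) from compound 3 to compound 4, 1.1-fold (0.02 log units) apart, within the scatter of two such steps. This shows that, on the two cores tested, the change behaved the same way in this cytotoxicity read-out, so the small step seen on the first core was a fair guide to the second; it does not show that the same would hold on any further core in the series, or in any other kind of test, since two pairs measured in one assay are a small sample and say nothing about why the step stays small.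

The compounds shown leave open whether a different group on that same oxygen, such as a benzoyl or a methyl group, or an amine in place of the oxygen, would also leave the number essentially unchanged. They also leave open whether a longer chain on the saturated carbon would alter the outcome of the hydroxy to acetoxy change.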